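Moving a hydroxyl on the benzamide: expected THP-1 cytotoxicity

A few compounds are considered here, and "the series" means these few. Any claim that something is new, unique, unknown or untested is made for them only; others in the source may bear on it.

Compound 1 `COc1ccc(-c2cnc(NC(=O)c3ccccc3O)n2C)cc1` gives, in a toxicity assay on THP-1 cells (Homo sapiens) for inhibition (on this read-out higher numbers stand for lower toxicity in this test and lower numbers for higher toxicity in this test), a limit of > 100000 nM.
Compound 2 `Cc1ccccc1-c1cnc(NC(=O)c2ccc(F)cc2)n1C` gives a limit of > 50000 nM in this assay.
Compound 3 `Cc1cccc(-c2cnc(NC(=O)c3ccc(F)cc3)n2C)c1` gives a limit of > 100000 nM in this assay.

Among the compounds with values here, compound 1 thus stands only at a limit of this assay, not at a number, and the same holds for compound 2 and compound 3, so no compound is separated from another. The step that the two limits leave unreadable from compound 2 to compound 3 is unreadable due to the two limits the limit of > 100000 nM in this assay, at which 2 of the 3 values shown sit, and (the limit of > 50000 nM in this assay, at which 1 of the 3 values shown sits). Compound 4 `COc1ccc(-c2cnc(NC(=O)c3cccc(O)c3)n2C)cc1` differs from compound 1 by 3-hydroxyphenyl in place of 2-hydroxyphenyl on a carbonyl carbon. Within the data shown here, no measured step speaks to this change, and every measured value sits at a limit of this assay, so compound 4 is expected to show no step beyond the scatter, as a number no higher from compound 1 to compound 4 (the limit leaves the size open). Compound 4 is therefore estimated at 100000 nM, with a range of 50000 nM to 200000 nM, most likely again reported only as a limit.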

Compound 4, half-maximal cytotoxic concentration: > 100000 nM
Compound 4 gave a limit, no number; the forecaster's own chance of this, stated with the estimate: 80%; the middle value sits exactly at the limit.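

In this assay compound 1 and compound 4 both stand only at a limit, and no step can be read between them. The compounds shown leave open whether 3-hydroxyphenyl in place of 2-hydroxyphenyl alters the half-maximal cytotoxic concentration at all.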